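Methoxy added to the benzamide of compound 3

A few compounds are considered here, and "the series" means these few. Any claim that something is new, unique, unknown or untested is made for them only; others in the source may bear on it.

Measured in a functional assay on MDA-MB-231 cells (Homo sapiens), read by microscopy and transwell migration, with a stated time of 24 h; a lower number here means a stronger inhibitor, a higher number a weaker inhibitor:
compound 1 `CCn1c(-c2ccccc2)cs/c1=N\C(=O)c1ccccc1`: 51.5 nM
compound 2 `COc1cc(-c2csc(NC(=O)c3ccccc3)n2)cc(OC)c1OC`: > 50000 nM (a limit of the assay, not a number)
compound 3 `COc1cc(-c2csc(N(C)C(=O)c3ccccc3)n2)cc(OC)c1OC`: 10000 nM

Only two of these results are actual numbers. Compound 3 gives 10000 nM, the higher of the two, and compound 1 gives 51.5 nM.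

Compound 4 `COc1ccccc1C(=O)N(C)c1nc(-c2cc(OC)c(OC)c(OC)c2)cs1` differs from compound 3 by methoxy in place of hydrogen on an aromatic carbon, phenyl to 2-methoxyphenyl (methoxy in place of hydrogen on an aromatic carbon).

One measured step lies close to this change: an at least 5.0-fold lower number from compound 2 to compound 3 (0.69 log units; beyond the scatter). That step is methyl in place of hydrogen on an amide-type nitrogen, and its size is only a bound because of the limit of > 50000 nM in this assay, at which 1 of the 3 values shown sits. It sits at a different place, so it sets neither size nor direction here. Among the measured compounds shown here, no measured step covers this aromatic carbon, and no step beyond the scatter is expected in this assay, though the uncertainty is wide.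

The expected step is a 1.3-fold lower number from compound 3 to compound 4 (0.10 log units; within the scatter). For compound 4 the estimate is 8000 nM, with an expected range from 1500 nM to 40000 nM.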

Compound 4, half-maximal inhibitory concentration: > 25000 nM
Compound 4 gave a limit, no number (the forecaster's own chance of this, stated with the estimate: 25%); middle value at least 3.1-fold (0.49 log units) away from the limit.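

In this assay, phenyl to 2-methoxyphenyl gives an at least 2.5-fold higher number from compound 3 to compound 4 (0.39 log units; beyond the scatter), so with the methylated amide in place, this aromatic carbon, ortho to a large group, does not take methoxy without a loss. The earlier compounds shown here offered only a step at the amide nitrogen and said nothing about the benzamide ring, which now proves open to change in the wrong direction. Compound 4 gives a limit of the assay, not a number, so the size of this loss remains a bound: the limit of > 25000 nM in this assay, at which 1 of the 4 values shown sits.

Going by these compounds, whether a fluorine or an amine at this carbon, or methoxy on another carbon of the ring, would fare the same stays open. Also open, on these data alone, is whether methoxy here would cost as much on the core of compound 1, which gives 51.5 nM.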